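Fluoro to ethoxy on the benzyl ring of an adenosine ligand

The compounds below may be only part of what the source reports. "The series", "measured", "known", "first", "only" and "open" are said of these compounds alone.

Compound 1 `O[C@@H]1[C@H](O)[C@@H]2C[C@@H]2[C@H]1n1cnc2c(NC3CCCCCCC3)nc(Cl)nc21` and compound 2 `O[C@@H]1[C@H](O)[C@@H]2C[C@@H]2[C@H]1n1cnc2c(NCc3ccccc3F)nc(Cl)nc21` share one core and differ only in the group on a nitrogen on an aromatic ring. In an assay on CHO cells for displacement of a labelled ligand from adenosine receptor A3 (Homo sapiens), with a stated time of 60 min (on this read-out lower numbers stand for stronger inhibition and higher numbers for weaker inhibition), compound 1 gives 1530 nM, while compound 2 gives 41.5 nM; the step of a 37-fold lower number from compound 1 to compound 2 (1.57 log units; beyond the scatter) leaves compound 2 with the lower of the two numbers. Compound 3 `CCOc1ccccc1CNc1nc(Cl)nc2c1ncn2[C@H]1[C@H](O)[C@H](O)[C@@H]2C[C@@H]21` keeps the benzyl on that nitrogen but carries ethoxy in place of fluoro on an aromatic carbon. For the measured compounds named here, no measured step touches this aromatic carbon: the single step known concerns the group on the nitrogen and, though large, says nothing about exchanging fluoro for ethoxy. The expected step is therefore a 1.4-fold higher number from compound 2 to compound 3 (0.16 log units; within the scatter), modest and not clearly beyond the scatter, with the direction uncertain. Compound 3 is accordingly estimated at 60 nM in this assay, with a range from 15 nM to 250 nM.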

Compound 3, inhibition constant: 15.2 nM
Beside the measured number, compound 3's estimate is 3.9-fold (0.60 log units) above it; low and high end bracket the measured number.
By their numbers in this assay, from the lowest: compound 3; then compound 2; then compound 1.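

In this assay, the exchange on the benzyl ring gives a 2.7-fold lower number from compound 2 to compound 3 (0.44 log units; beyond the scatter), so this aromatic carbon, ortho to a large group, takes ethoxy in place of fluoro with a modest gain rather than a loss. For the compounds shown here, the only earlier step, a 37-fold lower number from compound 1 to compound 2 (1.57 log units; beyond the scatter), concerned the group on the nitrogen, whereas this result shows that the number also responds to a change on the ring itself, where three heavy atoms, one of them oxygen, replace a single fluorine. Nothing in the data shown explains why the number falls with this exchange.

On these data alone, it remains open whether methoxy, hydroxyl or a propoxy chain on this carbon would lower the number further or raise it. As far as these compounds go, it is also open whether the oxygen or the two carbons of the ethoxy group account for the step.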